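Cyclopentyl for cyclohexyl on a shared anilinopyrimidine-type series

This account rests on a few compounds, and the source may have more. Where it says the series, first, only, none or still open, it means among the compounds named here.

Three compounds with a shared core were measured in an ADME assay on MT4 cells (Homo sapiens) for cytotoxicity, read by MTT assay; on this read-out lower numbers stand for higher toxicity in this test and higher numbers for lower toxicity in this test. Compound 1 `Cc1cnc(Nc2ccc(C#N)cc2)nc1SC1CCCCC1` gives 33400 nM. Compound 2 `N#Cc1ccc(Nc2nccc(NC3CC3)n2)cc1` gives 1190 nM. Compound 3 `Cc1cc(NC2CCCCC2)nc(Nc2ccc(C#N)cc2)n1` gives 340 nM, the lowest of the three numbers in this assay; the nearest is compound 2, whose number lies higher by a margin beyond the scatter, and the furthest is compound 1, whose number lies far higher still. No two of these compounds differ in one place only, so no single step between measured compounds can be read off.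

Compound 4 `Cc1cc(NC2CCCC2)nc(Nc2ccc(C#N)cc2)n1` has not yet been measured. It differs from compound 3 in one place: cyclopentyl in place of cyclohexyl on a nitrogen on an aromatic ring. This change removes one carbon from a saturated ring on a nitrogen on an aromatic ring and nothing else. Going by the values given here, with no measured step of this kind to draw on, the step from compound 3 to compound 4 is expected to be small, a 1.3-fold higher number from compound 3 to compound 4 (0.12 log units; within the scatter), and not beyond the scatter in either direction. Compound 4 is therefore estimated to give 450 nM in this assay, within a range from 150 nM to 1400 nM.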

Compound 4, half-maximal cytotoxic concentration: 310 nM
The estimate for compound 4 lay 1.5-fold (0.16 log units) above the measured number, within the range that was stated.
By their numbers in this assay, from the lowest: compounds 4 and 3 (each within the scatter of the next); then compound 2; then compound 1.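

In this assay, putting cyclopentyl in place of cyclohexyl on a nitrogen on an aromatic ring gives a 1.1-fold lower number from compound 3 to compound 4 (0.04 log units; within the scatter), so the two compounds cannot be told apart on this read-out. The earlier compounds shown here, none of which differed in one place only, could not show this: here, one carbon fewer in the saturated ring makes no difference beyond the scatter. No evidence is available that bears on what lies behind this result.

The compounds shown leave open whether a different kind of group on this nitrogen, such as a morpholine ring, a phenyl ring or an open butyl chain, would stay as close to compound 3. They also leave open whether the same exchange of cyclohexyl for cyclopentyl would read the same on the sulfur of compound 1.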